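Diaryl ether and thioether analogues in COLO 205 cytotoxicity

This account rests on a few compounds, and the source may have more. Where it says the series, first, only, none or still open, it means among the compounds named here.

Compound 1 `Nc1cc(N)c2nc(-c3ccccc3)c(Oc3ccc(Cl)c(Cl)c3)nc2c1` gives < 100000 nM in a functional assay on COLO 205 cells (Homo sapiens) for inhibition, read by sulforhodamine B assay, with a stated time of 48 h (on this read-out lower numbers stand for higher toxicity in this test and higher numbers for lower toxicity in this test), a limit of the assay rather than a number.
Compound 2 `Nc1cc(N)c2nc(-c3ccccc3)c(Sc3ccc(Cl)c(Cl)c3)nc2c1` gives < 100000 nM in this assay, again only a limit.

Compound 2 thus stands only at the assay limit. Within the data shown here, the single measured step, a step that the two limits leave unreadable from compound 1 to compound 2, is unreadable between two limits, and the limit of < 100000 nM in this assay, at which 2 of the 2 values shown sit, covers both measured values. Compound 3 `Nc1cc(N)c2nc(-c3ccccc3)c(Sc3ccc(F)cc3)nc2c1` differs from compound 2 by 4-fluorophenyl in place of 3,4-dichlorophenyl on a sulfur. Among the measured compounds shown here, no measured step bears on this change, so no direction beyond the scatter is expected for a step that the limit leaves unreadable from compound 2 to compound 3, and a bare limit remains the likeliest outcome. Compound 3 is therefore expected at 40000 nM, with a range of 8000 nM to 100000 nM.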

Compound 3, concentration lethal to 50% of the cells: < 100000 nM
Compound 3: no number, only a limit; the forecaster's own chance of this, stated with the estimate: 65%; the middle value does not contradict the limit.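

In this assay compound 3 gives < 100000 nM, only a limit of the assay. Among these compounds, no step among compound 1, compound 2 and compound 3 can be read. What stays open is whether these three compounds differ in toxicity at all: the limit of < 100000 nM in this assay, at which 3 of the 3 values shown sit.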